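Same atoms, joined differently: an expected stability value

The source may report more compounds than this note shows. Statements on the series, on what has been measured and on what is new or still open speak of the compounds shown alone.

Measured so far in an ADME assay on microsomes from liver (Homo sapiens) for metabolic stability, read by LC-MS, with a stated time of 10 min; a higher number here means that more of the compound is left, a lower number that less of the compound is left:
- compound 1 `CCCN(C[C@H]1Cc2c(cccc2N2CCNCC2)CN1)[C@H]1CCCc2cccnc21` gives 100%
- compound 2 `CN(C[C@H]1Cc2c(cccc2N2CCN(C3CC3)CC2)CN1)[C@H]1CCCc2cccnc21` gives 15.5%
- compound 3 `c1cnc2c(c1)CCC[C@@H]2N(CC1CCCCC1)C[C@H]1Cc2c(cccc2N2CCNCC2)CN1` gives 81.6%

Compound 2 stands lowest of the three numbers; its nearest neighbour is compound 3, which lies well above it, and compound 1 lies furthest above it. Both gaps are beyond the scatter.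

Compound 4 `CN(C[C@H]1Cc2c(cccc2N2CCN3CCC[C@H]3C2)CN1)[C@H]1CCCc2cccnc21` differs from compound 2 in one place: a group of 9 heavy atoms (7 carbon, 2 nitrogen; one five-membered non-aromatic ring with 1 hetero atom, one six-membered non-aromatic ring with 2 hetero atoms) in place of a group of 9 heavy atoms (7 carbon, 2 nitrogen; one three-membered non-aromatic ring of carbon only, one six-membered non-aromatic ring with 2 hetero atoms), on an aromatic carbon. For the measured compounds named here, the one measured step, a number 18.4 percentage points lower from compound 1 to compound 3 (beyond the scatter), concerns the substituent on the amine nitrogen, not the aromatic carbon changed here, so it does not bear on this change. Going by the values given here, no measured pair speaks to what a rearrangement of this group does in this assay.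

With no guide from the data, the expectation for compound 4 is a value near that of compound 2, with a wide range in either direction; the step of a number 9.5 percentage points higher from compound 2 to compound 4 (within the scatter) is the estimated outcome. Compound 4 is therefore estimated at 25%, between 8% and 55%.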

Compound 4, percent of the compound remaining: 36.6%
Compound 4: middle estimate off by 11.6 percentage points, on the low side; the measured number falls inside the stated range.
By their numbers in this assay, from the lowest: compound 2; then compound 4; then compound 3; then compound 1.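

For the compounds shown here, the step of a number 21.1 percentage points higher from compound 2 to compound 4 (beyond the scatter) in this assay is the first measured change at this aromatic carbon, and it shows that the number there can shift with how the atoms are joined, not only with which atoms are present. The group leaving and the group entering have the same heavy atoms and the same counts of hydrogen-bond donors and acceptors; they differ in that a five-membered ring with one hetero atom replaces the three-membered carbon ring, and the entering group has a defined stereocentre. No measurement available here explains this difference.

The compounds shown leave open what the entering group's opposite stereocentre would give, and what a morpholine on this aromatic carbon would give. They also leave open whether the step would hold with a propyl or cyclohexylmethyl group on the amine nitrogen.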